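The compounds below may be only part of what the source reports. "The series", "measured", "known", "first", "only" and "open" are said of these compounds alone.

Measured so far in a functional assay on DU-145 cells (Homo sapiens) for antiproliferative activity, read by MTT assay, with a stated time of 24 h; on this read-out lower numbers stand for stronger inhibition and higher numbers for weaker inhibition:
- compound 1 `c1ccc(-c2noc(-c3ccncc3)n2)cc1`: 657000 nM
- compound 2 `COc1ccc(-c2noc(C3CCNCC3)n2)cc1OC1CCCC1`: 57 nM

Compound 2 stands at the lower of the two numbers, and the gap to compound 1 lies far beyond the usual scatter. Going by the values given here, no step between measured compounds that differ in one place is available, so the two values only show that compound 2 is the stronger of the pair.

The next compound, compound 3 `COc1ccc(-c2noc(-c3ccc(O)cc3)n2)cc1OC1CCCC1`, differs from compound 2 in one place: 4-hydroxyphenyl in place of piperidin-4-yl on an aromatic carbon. Among the compounds with values here, no measured pair isolates this change, so nothing in the data fixes its size. The saturated ring leaves and an aromatic ring enters on the shared core; that enters a direction more like compound 1, whose number is 657000 nM. A loss of potency is expected, likely beyond the scatter but well short of compound 1.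

For compound 3 the estimated step of a 35-fold higher number from compound 2 to compound 3 (1.55 log units; beyond the scatter) points toward a higher number. Compound 3 is expected at 2000 nM, with a range from 200 nM to 40000 nM.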

Compound 3, half-maximal inhibitory concentration: 780 nM
Compound 3: middle estimate off by 2.6-fold (0.41 log units), on the high side, and the stated range covers the measured number.
By their numbers in this assay, from the lowest: compound 2; then compound 3; then compound 1.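

In this assay, this position, on an aromatic carbon of the five-membered aromatic ring, now has its first measured single change: 4-hydroxyphenyl in place of piperidin-4-yl gives a 14-fold higher number from compound 2 to compound 3 (1.14 log units; beyond the scatter). The position therefore responds strongly to the group it carries, even though the two groups match in computed donor and acceptor counts and in net charge, so those counts do not separate them. No measurement at hand accounts for the size of this step.

The step changes two things at once, the non-aromatic ring for an aromatic one and the ring nitrogen for a hydroxyl-bearing carbon, and the compounds shown do not separate them. A cyclohexyl ring or an unsubstituted phenyl ring at this position would tell these two changes apart, and a piperidin-4-yl bearing a methyl group on its nitrogen remains an open variation.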